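A few compounds are considered here, and "the series" means these few. Any claim that something is new, unique, unknown or untested is made for them only; others in the source may bear on it.

Compound 1 `Cc1ccc(-n2c(SCC(=O)NNC(=O)c3ccccc3O)nnc2-c2ccccc2O)cc1` was tested in an ADME assay on HCT-116 cells (Homo sapiens) for cytotoxicity (on this read-out higher numbers stand for lower toxicity in this test and lower numbers for higher toxicity in this test), and the result is only a limit of the assay, > 20000 nM, not a number. Two neighbours differ from it only in the group on the aromatic nitrogen of the shared core. Compound 2 `COc1ccccc1-n1c(SCC(=O)NNC(=O)c2ccccc2O)nnc1-c1ccccc1O` gives 20000 nM in this assay. Compound 3 `O=C(CSc1nnc(-c2ccccc2O)n1Cc1ccccc1)NNC(=O)c1ccccc1O` again reaches only a limit, > 20000 nM. The three comparisons, a number no higher from compound 1 to compound 2 (the limit leaves the size open), a step that the two limits leave unreadable from compound 1 to compound 3 and a number no lower from compound 2 to compound 3 (the limit leaves the size open), therefore cannot be read as steps of a known size, because of the limit of > 20000 nM in this assay, at which 2 of the 3 values shown sit.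

Compound 4 `Cc1ccc(-n2c(SCC(=O)NNC(=O)c3ccccc3O)nnc2-c2ccccc2)cc1` differs from compound 1 in another part of the molecule: hydrogen in place of hydroxy on an aromatic carbon. For the measured compounds named here, none of the measured steps changes this position, so none bears on it directly; the measured set only shows that every compound so far sits at or beyond the same high concentration. The expectation is therefore no step beyond the scatter, a number no higher from compound 1 to compound 4 (the limit leaves the size open), and compound 4 is estimated at 20000 nM, within a range from 10000 nM to 40000 nM.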

Compound 4, half-maximal cytotoxic concentration: 15000 nM
Estimate against measurement, compound 4: 1.3-fold (0.12 log units) above; the range from low to high includes it.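

Going from 2-hydroxyphenyl to phenyl at this position gives an at least 1.3-fold lower number from compound 1 to compound 4 (0.12 log units; that floor lies within the scatter) in this assay, and this is the only step shown that touches this position. As the floor of that step lies within the scatter, the result shows no real fall in the number on losing the hydroxy, but it does not rule one out. The true size of the step stays unread, because compound 1 sits at a limit of the assay: (the limit of > 20000 nM in this assay, at which 2 of the 4 values shown sit).

As far as these compounds go, whether an amine, a fluorine atom or a carboxylic acid in place of the hydroxy would move the number beyond the scatter remains open. Also open, from the compounds shown here alone, is whether the same change would read alike with the 2-methoxyphenyl of compound 2 or the benzyl of compound 3 on the aromatic nitrogen.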